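Replacing 4-fluoro-2-(trifluoromethyl)phenyl with 2-methoxyphenyl

This account rests on a few compounds, and the source may have more. Where it says the series, first, only, none or still open, it means among the compounds named here.

Measured in an ADME assay on microsomes from liver (Rattus norvegicus) for metabolic stability; on this read-out lower numbers stand for a shorter-lived compound and higher numbers for a longer-lived compound:
Compound 1 `CCS(=O)(=O)c1ccc(CNC(=O)c2ccc3c(c2)cc(Cc2ccccc2Br)n3C(C)C)cc1`: 0.2 h
Compound 2 `CCS(=O)(=O)c1ccc(CNC(=O)c2ccc3c(c2)cc(Cc2ccc(F)cc2C(F)(F)F)n3C(C)C)cc1`: 1.07 h

Compound 2, at 1.07 h, stands highest of the two measured compounds. Compound 3 `CCS(=O)(=O)c1ccc(CNC(=O)c2ccc3c(c2)cc(Cc2ccccc2OC)n3C(C)C)cc1` has not been measured, and its structure departs from that of compound 2 as follows: 2-methoxyphenyl in place of 4-fluoro-2-(trifluoromethyl)phenyl on a saturated chain carbon bound to an aromatic carbon. Among the measured compounds shown here, one measured step bears on this change: a 5.4-fold higher number from compound 1 to compound 2 (0.73 log units; beyond the scatter). In that modest step, the group now leaving came in. For the measured compounds named here, no measured compound carries 2-methoxyphenyl, so the evidence is thin. Going by the values given here, with only that step to go on, a downward step of similar size is expected in this assay. The estimated step is a 3.6-fold lower number from compound 2 to compound 3 (0.55 log units; beyond the scatter). Compound 3 is estimated at 0.3 h, with an expected range of 0.1 h to 0.9 h.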

Compound 3, half-life: 0.2 h
For compound 3 the middle estimate is 1.5-fold (0.18 log units) above the measured one; measured number inside the range.
By their numbers in this assay, from the lowest: compounds 1 and 3 (each within the scatter of the next); then compound 2.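

At this place, on a saturated chain carbon bound to an aromatic carbon, 2-methoxyphenyl gives up what 4-fluoro-2-(trifluoromethyl)phenyl had gained in this assay, with a 5.4-fold lower number from compound 2 to compound 3 (0.73 log units; beyond the scatter) on this change. Methoxy in place of bromo on an aromatic carbon shows no change at the digits printed from compound 1 to compound 3 (within the scatter), so the read-out does not separate these two groups. Nothing at hand gives a cause for either step. On these data alone, whether 2-(trifluoromethyl)phenyl without the fluoro would keep the higher number stays open, as does where plain phenyl or 2-chlorophenyl would fall.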